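Amide series, spiro amine against difluoropiperidine

The source may report more compounds than this note shows. Statements on the series, on what has been measured and on what is new or still open speak of the compounds shown alone.

Three compounds of the shared core have numbers in a functional assay on OVCAR-3 cells (Homo sapiens) for antiproliferative activity; a higher number here means that more compound is needed for the effect, a lower number that less compound is needed. Compound 1 `O=C(Nc1cccc(S(=O)(=O)N2CCCC2)c1)c1cccnc1N1CCC2(CC1)CC2` gives 4420 nM. Compound 2 `O=C(Nc1cccc(S(=O)(=O)C2COC2)c1)c1cccnc1N1CCC2(CC1)CC2` gives 12600 nM. Compound 3 `O=C(Nc1cccc(S(=O)(=O)C2CCCC2)c1)c1cccnc1N1CCC(F)(F)CC1` gives 4780 nM. Within these three, compound 3 stands second highest; its nearest neighbour is compound 1, within the scatter, and its furthest is compound 2, beyond the scatter. Among the measured compounds shown here, the only single-place step measured so far is a 2.9-fold higher number from compound 1 to compound 2 (0.45 log units; beyond the scatter), a modest rise when the sulfonyl substituent is swapped.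

Compound 4 `O=C(Nc1cccc(S(=O)(=O)C2CCCC2)c1)c1cccnc1N1CCC2(CC1)CC2` is not yet measured. The change from compound 3 is a group of 8 heavy atoms (7 carbon, 1 nitrogen; one three-membered non-aromatic ring of carbon only, one six-membered non-aromatic ring with 1 hetero atom) in place of a group of 8 heavy atoms (5 carbon, 1 nitrogen, 2 fluorine; one six-membered non-aromatic ring with 1 hetero atom), on an aromatic carbon. For the measured compounds named here, no measured pair covers this exchange at the amine position: compounds 1 and 2 both carry the entering group, compound 3 alone carries the leaving one, and compound 3 differs from compound 1 in two places, so their values can only be set side by side, where they lie within the scatter of each other. The measured step bears on the sulfonyl end, not on this one, and gives no direction for this assay. The expectation for compound 4 is therefore a step of a 1.1-fold lower number from compound 3 to compound 4 (0.03 log units; within the scatter), not beyond the scatter. Compound 4 is estimated at 4500 nM, with a range from 1800 nM to 11000 nM.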

Compound 4, half-maximal effective concentration: 1240 nM
Beside the measured number, compound 4's estimate is 3.6-fold (0.56 log units) above it; measured number outside the range, below it.
By their numbers in this assay, from the lowest: compound 4; then compounds 1 and 3 (each within the scatter of the next); then compound 2.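

Working notes: at the amine position, on an aromatic carbon next to the ring nitrogen, this assay now has a single-place comparison, with cyclopentyl held on the sulfonyl sulfur: a 3.9-fold lower number from compound 3 to compound 4 (0.59 log units; beyond the scatter), when the group with the three-membered carbon ring replaces 4,4-difluoropiperidin-1-yl, so this position moves the number even though the exchange keeps the same heavy-atom count. With that amine group fixed, cyclopentyl on the sulfonyl sulfur also separates from both earlier groups, with a 3.6-fold lower number from compound 1 to compound 4 (0.55 log units; beyond the scatter) against pyrrolidin-1-yl and a 10-fold lower number from compound 2 to compound 4 (1.01 log units; beyond the scatter) against oxetan-3-yl, which leaves compound 4 with the lowest number of the four, beyond the scatter of each of the others. No supporting data are available to explain either the amine step or the sulfonyl steps.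

Going by these compounds, the amine exchange has been read with cyclopentyl on the sulfonyl sulfur only, so it remains open whether the same step would hold with pyrrolidin-1-yl or oxetan-3-yl there. Also open, on these data alone, is where plain piperidin-1-yl at the amine position, or cyclohexyl on the sulfonyl sulfur, would fall relative to compound 4.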